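Swapping Trifluoromethyl for Sulfamoyl on the Shared Core

The source may report more compounds than this note shows. Statements on the series, on what has been measured and on what is new or still open speak of the compounds shown alone.

Three measured compounds share one core and differ only in a single group on an aromatic carbon. In a functional assay on L1210 cells (Mus musculus) for inhibition, read by MTT assay (a lower number here means a stronger inhibitor, a higher number a weaker inhibitor), compound 2 `N#CC1CN1C(=O)Nc1ccccc1`, which carries hydrogen there, gives 1200 nM. Compound 1 `N#CC1CN1C(=O)Nc1ccc(F)cc1`, which carries fluoro, gives 7300 nM in this assay, and compound 3 `N#CC1CN1C(=O)Nc1ccc(C(F)(F)F)cc1`, which carries trifluoromethyl, gives 7800 nM. Compound 3 thus stands at the highest of the three numbers, with compound 1 nearest: a 1.1-fold higher number from compound 1 to compound 3 (0.03 log units; within the scatter), whereas a 6.5-fold higher number from compound 2 to compound 3 (0.81 log units; beyond the scatter).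

Compound 4 `N#CC1CN1C(=O)Nc1ccc(S(N)(=O)=O)cc1` differs from compound 3 by sulfamoyl in place of trifluoromethyl on an aromatic carbon. Going by the values given here, no measured step introduces sulfamoyl, so the expectation rests on the two steps already seen: a 6.5-fold higher number from compound 2 to compound 3 (0.81 log units; beyond the scatter), and a 6.1-fold lower number from compound 1 to compound 2 (0.78 log units; beyond the scatter). Both substituted compounds sit well above compound 2 and close to each other, so compound 4 is expected to stay near compound 3, with a 1.2-fold lower number from compound 3 to compound 4 (0.08 log units; within the scatter) falling within the scatter. The estimate for compound 4 in this assay is 6500 nM, in a range from 1500 nM to 28000 nM.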

Compound 4, half-maximal inhibitory concentration: > 38000 nM
Compound 4: no number, only a limit; the forecaster's own chance of this, stated with the estimate: 5%; at least 5.8-fold (0.76 log units) between middle value and limit.
By their numbers in this assay, from the lowest: compound 2; then compounds 1 and 3 (each within the scatter of the next). At a limit, above all of these: compound 4.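

In this assay compound 4 gives > 38000 nM, which is a limit of the assay and not a number. Fluoro and trifluoromethyl gave values within the scatter of each other, which could suggest that substituents here all cost about the same, but sulfamoyl goes beyond both: an at least 5.2-fold higher number from compound 1 to compound 4 (0.71 log units; beyond the scatter), and an at least 4.8-fold higher number from compound 3 to compound 4 (0.68 log units; beyond the scatter). Measured against the unsubstituted compound, the change is larger still, an at least 31-fold higher number from compound 2 to compound 4 (1.50 log units; beyond the scatter), so at this position the identity of the group matters, not merely whether hydrogen is replaced.

The limit leaves the true size of all three steps open. The compounds shown also cannot tell which feature of sulfamoyl goes with the change, and an amine or a carboxylic acid on the same aromatic carbon would be a further test.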